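Heteroaryl swap at the chain carbon of the shared core

This account rests on a few compounds, and the source may have more. Where it says the series, first, only, none or still open, it means among the compounds named here.

Series of three measured analogues on one core: compound 1 `CC(C)C(Cc1ncc[nH]1)c1ccc(-c2ccc3cccc(F)c3c2)[nH]c1=O`, compound 2 `CC(C)C(c1ncco1)c1ccc(-c2ccc3cccc(F)c3c2)[nH]c1=O` and compound 3 `CC(C)C(Cc1nnn[nH]1)c1ccc(-c2ccc3cccc(F)c3c2)[nH]c1=O`. In a functional assay on CHO cells for antagonist activity at prostaglandin E2 receptor EP3 subtype (Homo sapiens), read by cAMP accumulation (a lower number here means a stronger inhibitor, a higher number a weaker inhibitor), compound 1 gives 76 nM, compound 2 gives 64 nM and compound 3 gives 134 nM. Compound 3 therefore holds the highest of the three numbers; its gap to compound 1 is within the scatter, its gap to compound 2 is beyond it.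

The next compound is compound 4 `Cc1c[nH]c(C(c2ccc(-c3ccc4cccc(F)c4c3)[nH]c2=O)C(C)C)n1`. It differs from compound 3 by 4-methyl-1H-imidazol-2-yl in place of (1H-tetrazol-5-yl)methyl on a saturated chain carbon bound to an aromatic carbon and a saturated chain carbon. Among the measured compounds shown here, two measured steps bear on this. The step of a 1.8-fold higher number from compound 1 to compound 3 (0.25 log units; within the scatter) covers the tetrazole-for-imidazole exchange at the same ring position, the methylene retained. The step of a 2.1-fold higher number from compound 2 to compound 3 (0.32 log units; beyond the scatter) covers loss of the methylene together with a ring change. For the measured compounds named here, compound 4 reverses both features at once, returning to an imidazole and to direct attachment, with an added methyl on the ring, for which no measured pair gives guidance.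

The expectation for compound 4 in this assay is a modest move to a lower number, near compounds 1 and 2, i.e. a step of a 1.9-fold lower number from compound 3 to compound 4 (0.28 log units; within the scatter). Compound 4 is estimated at 70 nM, with a likely range from 30 nM to 170 nM.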

Compound 4, half-maximal inhibitory concentration: 36 nM
Compound 4: middle estimate off by 1.9-fold (0.29 log units), on the high side; low and high end bracket the measured number.
By their numbers in this assay, from the lowest: compounds 4, 2, 1 and 3 (each within the scatter of the next, the first and the last beyond it).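

In this assay, among the compounds shown here, 4-methyl-1H-imidazol-2-yl on this saturated chain carbon gives a 3.7-fold lower number from compound 3 to compound 4 (0.57 log units; beyond the scatter) and also a 2.1-fold lower number from compound 1 to compound 4 (0.32 log units; beyond the scatter), so compound 1, which no earlier step separated from the other compounds beyond the scatter, now stands apart from compound 4. Against 1,3-oxazol-2-yl the same group gives a 1.8-fold lower number from compound 2 to compound 4 (0.25 log units; within the scatter), which leaves compound 2 and compound 4 unseparated, so these two ring groups carried on the chain carbon without a methylene read alike at this position. The absence of the methylene does not account for the gain on its own terms, as compound 2 gives only a 1.2-fold lower number from compound 1 to compound 2 (0.07 log units; within the scatter), and the step to compound 4 joins that change with the added methyl, so the two cannot be told apart here.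

No measurement of any property of these compounds bears on the steps, and the series offers no explanation for them. The compounds shown leave open what the unsubstituted 1H-imidazol-2-yl group would give when carried on the chain carbon without a methylene, and how an amine, a carboxylic acid or a longer chain would read at the same place.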